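The source may report more compounds than this note shows. Statements on the series, on what has been measured and on what is new or still open speak of the compounds shown alone.

Compounds measured so far:

compound 1, `CC[N+]1(C)CCc2c(sc(NC(=O)Nc3ccc(Cl)cc3)c2C(N)=O)C1` — 1960 nM
compound 2, `C[N+]1(CC2CCCC2)CCc2c(sc(NC(=O)Nc3ccc(Cl)cc3)c2C(N)=O)C1` — 200 nM
compound 3, `CC(C)[N+]1(C)CCc2c(sc(NC(=O)Nc3ccc(Cl)cc3)c2C(N)=O)C1` — 960 nM

In a functional assay (strain AB) with Danio rerio as the target, read by microscopy, with a stated time of 1 h (a higher number here means that more compound is needed for the effect, a lower number that less compound is needed), compound 1 gives the highest of the three numbers; compound 3 sits nearest to it with a 2.0-fold lower number from compound 1 to compound 3 (0.31 log units; beyond the scatter), and compound 2 lies furthest away with a 9.8-fold lower number from compound 1 to compound 2 (0.99 log units; beyond the scatter). The unmeasured compound 4, `CC[N+]1(CC)CCc2c(sc(NC(=O)Nc3ccc(Cl)cc3)c2C(N)=O)C1`, shares the core of compound 1 and differs from it only at the charged ring nitrogen: methyl in place of hydrogen on a saturated chain carbon bound to an amine nitrogen in a ring.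

Among the compounds with values here, two measured steps bear on this change. The step from compound 1 to compound 3, which adds a methyl at the same kind of place, gave a 2.0-fold lower number from compound 1 to compound 3 (0.31 log units; beyond the scatter). The step from compound 1 to compound 2, which puts a larger ring-bearing group on that nitrogen, gave a 9.8-fold lower number from compound 1 to compound 2 (0.99 log units; beyond the scatter). Both point the same way, and the smaller enlargement in compound 4 sits closer to compound 3 than to compound 2. A modest lowering of the number is therefore expected, of about a 2.0-fold lower number from compound 1 to compound 4 (0.29 log units; within the scatter), with the scatter of this assay leaving room for no change at all.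

Compound 4 is estimated at 1000 nM, within a range of 450 nM to 2200 nM.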

Compound 4, half-maximal effective concentration: 450 nM
Beside the measured number, compound 4's estimate is 2.2-fold (0.35 log units) above it; low and high end bracket the measured number.
By their numbers in this assay, from the lowest: compound 2; then compound 4; then compound 3; then compound 1.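

In this assay, the methyl that turns a methyl group on the ring nitrogen into ethyl gives a 4.4-fold lower number from compound 1 to compound 4 (0.64 log units; beyond the scatter), which is larger than the step for methyl in place of hydrogen at the carbon also bound to a saturated chain carbon, a 2.0-fold lower number from compound 1 to compound 3 (0.31 log units; beyond the scatter) in this case. The place where the methyl enters on this nitrogen therefore goes with a different size of step, and a ring is not needed for a lowering of this order, although compound 2 at 200 nM still has the lowest number of the four. No measurement at hand accounts for the size of this step.

The compounds shown leave open whether the number keeps falling with a longer chain such as propyl or butyl on this nitrogen. They also do not tell how a hydroxyethyl group there would read.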